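A few compounds are considered here, and "the series" means these few. Any claim that something is new, unique, unknown or untested is made for them only; others in the source may bear on it.

Compound 1 `N#Cc1c(-c2nnc(-c3nn(-c4ccccc4)c(-c4ccccc4)c3C#N)c3nn(-c4ccccc4)cc23)nn(-c2ccccc2)c1-c1ccccc1`: 9120 nM
Compound 2 `N#Cc1c(-c2nnc(-c3nn(-c4ccccc4)c(-c4ccccc4)c3C#N)c3nn(-c4ccc(Cl)cc4)cc23)nn(-c2ccccc2)c1-c1ccccc1`: > 100000 nM, a limit of the assay
Compound 3 `N#Cc1c(-c2nnc(-c3ccccc3)c3nn(-c4ccccc4)cc23)nn(-c2ccccc2)c1-c1ccccc1`: > 100000 nM, a limit of the assay

All three were tested in a functional assay on OVCAR-5 cells (Homo sapiens) for inhibition, read by sulforhodamine B assay, with a stated time of 48 h; on this read-out lower numbers stand for stronger inhibition of growth and higher numbers for weaker inhibition of growth. Compound 1 gives 9120 nM. Compound 2 reaches only the limit of the assay, > 100000 nM. From the compounds shown here alone, the change from compound 1 to compound 2 is chloro in place of hydrogen on an aromatic carbon, and it made an at least 10-fold higher number from compound 1 to compound 2 (1.04 log units; beyond the scatter); its true size is unknown because of the limit of > 100000 nM in this assay, at which 2 of the 3 values shown sit. Compound 3 likewise gives only a limit, > 100000 nM. How the core of compound 3 differs from that of compound 1 is not broken down here. Among the compounds with values here, compound 4 `N#Cc1c(-c2nnc(-c3ccccc3)c3nn(-c4ccc(Cl)cc4)cc23)nn(-c2ccccc2)c1-c1ccccc1` carries the same change as the one from compound 1 to compound 2, now on the core of compound 3: chloro in place of hydrogen on an aromatic carbon. Compound 3 already sits at the limit, so the expected step is a step that the limit leaves unreadable from compound 3 to compound 4, most likely another limit. Compound 4 is estimated at 200000 nM.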

Compound 4, concentration for 50% growth inhibition: 8940 nM
For compound 4 the middle estimate is 22-fold (1.35 log units) above the measured one, and the stated range ends above it.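

Swapping phenyl for 4-chlorophenyl gave an at least 11-fold lower number from compound 3 to compound 4 (1.04 log units; beyond the scatter), the opposite direction to the step on the core of compound 1, so this change does not carry over predictably from one core to the other: the same change on two cores in this assay, an at least 10-fold higher number (1.04 log units; beyond the scatter) from compound 1 to compound 2 and an at least 11-fold lower number (1.04 log units; beyond the scatter) from compound 3 to compound 4, at least 120-fold (2.08 log units) apart, beyond the scatter of two such steps. From the compounds shown here alone, the true size of both steps remains unknown, since each involves a limit rather than a number: the limit of > 100000 nM in this assay, at which 2 of the 4 values shown sit. The data do not show why the direction reverses, and two cores are too few to establish a rule for the series.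

Going by these compounds, it remains open whether fluoro, methoxy or an amine in place of the chloro would also split the two cores. The compounds shown also leave open which part of the core decides the direction.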